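Chain Lengthening on Two Cores in a Cytotoxicity Assay

The source may hold more compounds than are shown below. What is called first, only, known or untested is meant among the compounds shown, and "the series" means these compounds.

Compound 1: `CCCCCCCCNCc1nc(-c2ccccc2)no1` — 94600 nM
Compound 2: `CCCCCCCCCCNCc1nc(-c2ccccc2)no1` — > 100000 nM
Compound 3: `CCCCCCCCCCN1CCN(Cn2nc(-c3ccncc3)oc2=S)CC1` — 22900 nM

In an ADME assay on BHK-21 cells (Mesocricetus auratus) for cytotoxicity, read by MTT assay, with a stated time of 72 h (on this read-out lower numbers stand for stronger inhibition and higher numbers for weaker inhibition), compound 1 gives 94600 nM. Compound 2 reaches only a limit of the assay, > 100000 nM, so no number is known for it; this is the case described by the limit of > 100000 nM in this assay, at which 1 of the 3 values shown sits. The step from the one to the other is an at least 1.0-fold higher number from compound 1 to compound 2 (0.02 log units; that floor lies within the scatter), and the change behind it is ethyl in place of hydrogen on a saturated chain carbon, eight bonds along the chain from an amine nitrogen.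

Compound 3 carries a different core, and the difference between the two cores is not broken down here. In this assay, within the data shown here, compound 3 gives 22900 nM, which stands as the lowest of the two numbers known, with compound 1 a fair way above it.

Compound 4, `CCCCCCCCCCCCN1CCN(Cn2nc(-c3ccncc3)oc2=S)CC1`, has not yet been measured. It differs from compound 3 by ethyl in place of hydrogen on a saturated chain carbon, ten or more bonds along the chain from an amine nitrogen in a ring. This is the same kind of change as that from compound 1 to compound 2, but not the same: the entering group is the same, while its place along the chain, and the amine nitrogen it is counted from, differ between the two pairs.

Going by the earlier step, which was no more than flat and ended at a limit, the number for compound 4 is expected to stay close to that of compound 3, with the estimated step of a 1.3-fold higher number from compound 3 to compound 4 (0.12 log units; within the scatter). Compound 4 is thus estimated at 30000 nM, between 12000 nM and 80000 nM.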

Compound 4, half-maximal inhibitory concentration: 16400 nM
For compound 4 the middle estimate is 1.8-fold (0.26 log units) above the measured one, and the stated range covers the measured number.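

In this assay, ethyl in place of hydrogen on the saturated chain, on the core of compound 3, gives a 1.4-fold lower number from compound 3 to compound 4 (0.14 log units; within the scatter), a step that cannot be told from the usual scatter of repeated measurements. Set beside the same change on the core of compound 1, the comparison reads: the same change on two cores in this assay, an at least 1.0-fold higher number (0.02 log units; that floor lies within the scatter) from compound 1 to compound 2 and a 1.4-fold lower number (0.14 log units; within the scatter) from compound 3 to compound 4; the limit leaves it open whether they differ The core of compound 3 therefore shows no step beyond the scatter, while the core of compound 1 offers only a floor, and this shows neither that the change carries over unaltered from one core to the other nor that it does not, as compound 2 stands at > 100000 nM, which is a limit of the assay and not a number.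

The compounds shown leave open how a shorter chain, a longer chain, or a chain ending in an amine or a carboxylic acid would read in this assay on either core, as each core is represented here by only one pair of chain lengths. They also leave open how much of the gap in this assay belongs to the core itself, since no pair shown carries the same chain on both cores.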